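This account rests on a few compounds, and the source may have more. Where it says the series, first, only, none or still open, it means among the compounds named here.

Working notes, values in an ADME assay on Vero cells (Chlorocebus sabaeus) for cytotoxicity, read by MTT assay; on this read-out higher numbers stand for lower toxicity in this test and lower numbers for higher toxicity in this test:

- Compound 1 `Cn1nc(C(F)(F)F)cc1C(=O)Nc1ccc(S(=O)(=O)N2CCCCCC2)cc1` gives > 300000 nM, a limit.
- Compound 2 `Cn1nc(C(F)(F)F)cc1C(=O)Nc1ccc(S(=O)(=O)OC2CCCCC2)cc1` gives > 300000 nM, a limit.
- Compound 3 `Cn1nc(C(F)(F)F)cc1C(=O)Nc1ccc(S(=O)(=O)N2CCC(NC(=O)OC(C)(C)C)CC2)cc1` gives > 300000 nM, a limit.

Compound 2 stands only at a limit, and the 2 further values are limits too. Still unmeasured is compound 4 `Cn1nc(C(F)(F)F)cc1C(=O)Nc1ccc(S(=O)(=O)N2CCCC(C(=O)O)C2)cc1`, which has 3-carboxypiperidin-1-yl in place of cyclohexyloxy on a sulfonyl sulfur.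

Among the measured compounds shown here, the one measured step bearing on this change also alters the group on the sulfonyl sulfur: a step that the two limits leave unreadable from compound 1 to compound 2. It has no readable size. The other measured information is the limit of > 300000 nM in this assay, at which 3 of the 3 values shown sit, which covers compound 1, compound 2 and compound 3 alike, with none going against it.

No step beyond the usual scatter is therefore expected in this assay, and no direction can be assigned. The estimated change is a number no higher from compound 2 to compound 4 (the limit leaves the size open). For compound 4 the expected value is 300000 nM, with an estimated range from 120000 nM to 600000 nM.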

Compound 4, half-maximal cytotoxic concentration: > 300000 nM
Compound 4 ended at the assay's limit; the forecaster's own chance of this, stated with the estimate: 85%; the middle value lies on the limit itself.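

Steps linking compound 4 with compound 1 and compound 2 cannot be read in this assay, because all three stand at a limit: the limit of > 300000 nM in this assay, at which 4 of the 4 values shown sit.

The compounds shown leave open where their true values lie and whether any group on the sulfonyl sulfur changes them.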